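From compound 1 to compound 3: one side group replaced

The compounds below may be only part of what the source reports. "The series", "measured", "known", "first", "only" and "open" are said of these compounds alone.

Compound 1 `Cc1cc(C)c(CN2CCc3c(Cl)cc([C@H](CO)[C@H]4CCOC4)c(Cl)c3C2=O)c(=O)[nH]1` gives 570000 nM
Compound 2 `COc1cc(C)[nH]c(=O)c1CN1CCc2c(Cl)cc(C(OC)C3CCN(C(=O)CO)CC3)c(Cl)c2C1=O` gives 480000 nM; 453000 nM (2 entries)

For the measured compounds named here, in a physicochemical assay for solubility, measured as kinetic solubility (on this read-out lower numbers stand for lower solubility and higher numbers for higher solubility), compound 1 holds the only single number so far (570000 nM), while compound 2 has repeated entries instead of one number (the several entries of compound 2 in this assay, 480000 nM; 453000 nM (2 entries)). Compound 3 `Cc1cc(C)c(CN2CCc3c(Cl)cc(-c4c(C)noc4C)c(Cl)c3C2=O)c(=O)[nH]1` keeps the core of compound 1 but exchanges one group on an aromatic carbon (a group of 7 heavy atoms (5 carbon, 1 nitrogen, 1 oxygen; one five-membered aromatic ring with 2 hetero atoms) in place of a group of 8 heavy atoms (6 carbon, 2 oxygen; one five-membered non-aromatic ring with 1 hetero atom), on an aromatic carbon). The group that enters is 3,5-dimethyl-1,2-oxazol-4-yl. Going by the values given here, no measured pair shows such an exchange, so the expectation starts from compound 1 at 570000 nM and from the structural change, in which the leaving group carries a hydrogen-bond donor and the entering group carries none. In this assay a fall well beyond the usual scatter is expected, estimated as a 9.5-fold lower number from compound 1 to compound 3 (0.98 log units; beyond the scatter) with wide uncertainty. Compound 3 is expected near 60000 nM (estimated range 8000 nM to 300000 nM).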

Compound 3, solubility: 93000 nM
The estimate for compound 3 lay 1.6-fold (0.19 log units) below the measured number; measured number inside the range.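

In this assay, for the compounds shown here, the exchange of the group on this aromatic carbon for 3,5-dimethyl-1,2-oxazol-4-yl gives a 6.1-fold lower number from compound 1 to compound 3 (0.79 log units; beyond the scatter) and so provides the first single change that can be read. It shows that the read-out responds to what sits at this place on the shared core, in a step that takes away a hydrogen-bond donor and 2 defined stereocentres and brings in a five-membered aromatic ring. Nothing measured here bears on why the number falls.

Going by these compounds alone, the single step changes all these features at once, so it cannot tell which of them accounts for the fall. On these data alone, how an amine, a carboxylic acid or a simple hydroxymethyl group on the same aromatic carbon would read also remains open.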